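A Trifluoromethyl in Place of Methyl on Compound 1

The source may hold more compounds than are shown below. What is called first, only, known or untested is meant among the compounds shown, and "the series" means these compounds.

Of the compounds shown here, three have so far been measured in a functional assay for agonist activity at Alpha-1B adrenergic receptor (Homo sapiens); a lower number here means a smaller maximal response, a higher number a larger maximal response. Compound 1 `CSc1ccc(C)cc1NCC1=NCCN1` gives 96% in this assay, the second highest of the three numbers. Compound 2 `CS(=O)(=O)c1ccc(Cl)cc1NCC1=NCCN1` gives 103%, a value within the scatter of that of compound 1. Compound 3 `CSc1c(F)cccc1NCC1=NCCN1` gives 48%, the number furthest from compound 1 and beyond the scatter. Compound 4 `CSc1ccc(C(F)(F)F)cc1NCC1=NCCN1` has not yet been measured. It differs from compound 1 in one place: trifluoromethyl in place of methyl on an aromatic carbon. Among the compounds with values here, no step between measured compounds matches this change, so its direction cannot be read from the data. The expected step is small, a number 6 percentage points lower from compound 1 to compound 4 (within the scatter), not beyond the scatter. Compound 4 is therefore estimated at 90%, within 70% to 105%.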

Compound 4, largest response reached (reported as maximum), in percent of the reference or control that the assay uses: 114%
For compound 4 the middle estimate is 24 percentage points below the measured one; measured number outside the range, above it.
By their numbers in this assay, from the lowest: compound 3; then compounds 1 and 2 (each within the scatter of the next); then compound 4.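

In this assay, within the data shown here, trifluoromethyl in place of methyl on this aromatic carbon, para to the methylsulfanyl group, gives a number 18 percentage points higher from compound 1 to compound 4 (beyond the scatter) and is the first change read at this position. Here, four heavy atoms in place of one do not lower the maximal response but raise it modestly. Nothing available accounts for this rise. From the compounds shown here alone, whether a methoxy group, a nitrile or an amine on the same carbon would keep this response remains open. So does whether an ethyl group would fall nearer compound 1 or compound 4.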